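A methoxy added to an inactive compound

The source may report more compounds than this note shows. Statements on the series, on what has been measured and on what is new or still open speak of the compounds shown alone.

- Compound 1 `CCN1CCN(c2ccc(S(=O)(=O)Oc3ccccc3OC)cc2)C1=O`: > 100000 nM
- Compound 2 `CCCCN1CCN(c2ccc(S(=O)(=O)Oc3ccccc3)cc2)C1=O`: > 100000 nM

Both results come from a functional assay on M21 cells (Homo sapiens) for antiproliferative activity, read by sulforhodamine B assay, with a stated time of 48 h; on this read-out lower numbers stand for stronger inhibition and higher numbers for weaker inhibition. Compound 2 gives > 100000 nM, which is a limit and not a number. The two results share one position: the limit of > 100000 nM in this assay, at which 2 of the 2 values shown sit. Compound 3 `CCCCN1CCN(c2ccc(S(=O)(=O)Oc3ccccc3OC)cc2)C1=O` differs from compound 2 by methoxy in place of hydrogen on an aromatic carbon, with the methoxy ortho to a large group. Compound 1 already carries this methoxy, and its result is also a limit, > 100000 nM. No direction of change can therefore be expected, and any step should stay within the scatter. The expected step of a number no higher from compound 2 to compound 3 (the limit leaves the size open) is correspondingly small. Compound 3 is estimated at 100000 nM, with an expected range of 30000 nM to 300000 nM.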

Compound 3, half-maximal inhibitory concentration: > 100000 nM
Compound 3 ended at the assay's limit; the forecaster's own chance of this, stated with the estimate: 75%; the middle value lies on the limit itself.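

Compound 3 gives > 100000 nM, which is a limit and not a number. The steps to compound 3 from compound 1 and compound 2 cannot be read, as all three share one position: the limit of > 100000 nM in this assay, at which 3 of the 3 values shown sit.

The compounds shown leave open whether the methoxy or the longer chain changes the result in this assay at all.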